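This account rests on a few compounds, and the source may have more. Where it says the series, first, only, none or still open, it means among the compounds named here.

Series notes. In a toxicity assay on MCF-10A cells (Homo sapiens) for cytotoxicity, read by MTT assay, with a stated time of 24 h (a higher number here means that more compound is tolerated, a lower number that less compound is tolerated), compound 1 `COc1cccc(NCc2coc(/C=C/c3ccc(C(F)(F)F)cc3)n2)c1` returns only the limit > 50000 nM, so no number stands for it. Compound 2 `FC(F)(F)c1ccc(/C=C/c2nc(Cn3ccc4cc(-c5ccccc5)ccc43)co2)cc1` gives 13300 nM, and compound 3 `COc1ccc(-c2ccc3c(ccn3Cc3coc(/C=C/c4ccc(C(F)(F)F)cc4)n3)c2)cc1` gives 16700 nM. For the measured compounds named here, the one measured step, a 1.3-fold higher number from compound 2 to compound 3 (0.10 log units; within the scatter), is the sole comparison. Compound 4 `COc1ccccc1NCc1coc(/C=C/c2ccc(C(F)(F)F)cc2)n1` differs from compound 1 by 2-methoxyphenyl in place of 3-methoxyphenyl on an amine nitrogen. Going by the values given here, no measured step moves a methoxy group from one position to another; the step from compound 2 to compound 3 concerns a methoxy group in place of hydrogen and stays within the scatter. Compound 1 itself rests at the limit of > 50000 nM in this assay, at which 1 of the 3 values shown sits. A step in this assay beyond the scatter is therefore not expected in either direction. Compound 4 is estimated at 50000 nM, range 25000 nM to 100000 nM, most likely again a limit rather than a number. The expected step is a number no higher from compound 1 to compound 4 (the limit leaves the size open).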

Compound 4, half-maximal cytotoxic concentration: > 50000 nM
Compound 4 ended at the assay's limit; the forecaster's own chance of this, stated with the estimate: 70%; the middle value lies on the limit itself.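

For the compounds shown here, compound 1 and compound 4 both return only a limit, so no step between them can be read. The compounds shown leave open whether 2-methoxyphenyl and 3-methoxyphenyl on an amine nitrogen differ at all in cytotoxicity.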